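Bromo for Chloro: Expectation in a Cytotoxicity Assay

This account rests on a few compounds, and the source may have more. Where it says the series, first, only, none or still open, it means among the compounds named here.

Measured compounds:
compound 1, `C(=N/Nc1nc(-c2ccccc2)cs1)\c1ccc(-n2ccnc2)cc1`: 21.8%
compound 2, `Clc1ccc(-c2csc(N/N=C/c3ccc(-n4ccnc4)cc3)n2)cc1`: 32.1%

In an ADME assay on THP-1 cells (Homo sapiens) for cytotoxicity, read by MTT assay, tested at 50 ug/mL (on this read-out higher numbers stand for more inhibition at the one concentration tested (going by the name of the read-out) and lower numbers for less inhibition), compound 2 gives 32.1%, the highest of the two numbers. For the measured compounds named here, the nearest is compound 1, which in this assay gives 21.8%, and the only measured step is a number 10.3 percentage points higher from compound 1 to compound 2 (beyond the scatter), a step of chloro in place of hydrogen on an aromatic carbon.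

Compound 3, `Brc1ccc(-c2csc(N/N=C/c3ccc(-n4ccnc4)cc3)n2)cc1`, differs from compound 2 by bromo in place of chloro on an aromatic carbon. Going by the values given here, no measured step covers this exchange of one halogen for another; the single step available concerns the arrival of chloro where hydrogen stood, not its replacement by bromo, so it bears on the question only indirectly, as a sign that the group at this position is read by this assay at all. Since the counted difference is a single heavy atom with no change in ring count, donors, acceptors or charge, compound 3 is expected to give a number close to that of compound 2, with the estimated step of a number 1.9 percentage points higher from compound 2 to compound 3 (within the scatter) not beyond the scatter. Compound 3 is therefore estimated at 34%, in the range 22% to 46%.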

Compound 3, a percentage reported as inhibition, at one concentration (the size of the read-out at that concentration, not a potency): 36.8%
Beside the measured number, compound 3's estimate is 2.8 percentage points below it; low and high end bracket the measured number.
By their numbers in this assay, from the lowest: compound 1; then compounds 2 and 3 (each within the scatter of the next).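

In this assay the exchange of chloro for bromo gives a number 4.7 percentage points higher from compound 2 to compound 3 (within the scatter) and so does not separate 4-chlorophenyl from 4-bromophenyl at this place, on the six-membered aromatic ring and para to a large group. For the compounds shown here, measured against hydrogen on the same carbon, bromo gives a number 15 percentage points higher from compound 1 to compound 3 (beyond the scatter) and chloro gives a number 10.3 percentage points higher from compound 1 to compound 2 (beyond the scatter) so both halogens now stand apart from hydrogen, whereas the earlier compounds showed this for chloro alone, and within this set of compounds the presence of a halogen at this place counts for more than which of the two it is. Nothing on hand accounts for why hydrogen and the two halogens read as they do in this assay.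

The compounds shown leave open how fluoro, iodo, methoxy, an amine or a carboxylic acid would read at this same place, and so whether the higher numbers belong to halogens in particular or to any group that replaces hydrogen there. They also leave open whether bromo in place of chloro would read the same way elsewhere on the shared core.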